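Fluoro to Methylcarbamoyl: A Stability Outlook

The compounds below may be only part of what the source reports. "The series", "measured", "known", "first", "only" and "open" are said of these compounds alone.

Measured compounds:
- compound 1 `Clc1cccc2c(-c3ccc4ccccc4n3)c[nH]c12`: 0.283 h
- compound 2 `Cc1cccc2c(-c3ccc4c(F)cccc4n3)c[nH]c12`: 0.217 h
- compound 3 `Cc1c(F)ccc2c(-c3ccc4ccccc4n3)c[nH]c12`: 0.433 h

All three compounds were tested in an ADME assay on microsomes from liver (Homo sapiens) for metabolic stability, using NADPH, with a stated time of 40 min, tested at 2 uM; on this read-out higher numbers stand for a longer-lived compound and lower numbers for a shorter-lived compound. Compound 1 gives 0.283 h, compound 2 gives 0.217 h and compound 3 gives 0.433 h. Compound 2 has the lowest of the three numbers, but its nearest neighbour, compound 1, and its furthest, compound 3, both lie within the scatter of it, so the three compounds cannot be told apart on this read-out. Among the measured compounds shown here, no pair among them differs in a single place, so no step between measured compounds is available to guide an expectation.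

Compound 4 `CNC(=O)c1cccc2nc(-c3c[nH]c4c(C)cccc34)ccc12` has not yet been measured. Compared with compound 2 it carries one change: methylcarbamoyl in place of fluoro on an aromatic carbon. With no measured step of this kind in hand, and three half-lives that sit together within the scatter, there is little ground for predicting a large move in either direction. Compound 4 is therefore expected to stay close to compound 2, with a step of a 1.4-fold higher number from compound 2 to compound 4 (0.14 log units; within the scatter) that may not exceed the scatter. The estimate for compound 4 is 0.3 h, with a range from 0.13 h to 0.75 h.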

Compound 4, half-life: 0.983 h
The estimate for compound 4 lay 3.3-fold (0.52 log units) below the measured number; the whole stated range lies below it.
By their numbers in this assay, from the lowest: compounds 2, 1 and 3 (each within the scatter of the next); then compound 4.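

In this assay, among the compounds shown here, methylcarbamoyl in place of fluoro on an aromatic carbon gives a 4.5-fold higher number from compound 2 to compound 4 (0.66 log units; beyond the scatter), the first single-place step available and one that lies beyond the scatter, whereas the earlier compounds offered no such step and their numbers could not be told apart. It shows that this place, on a six-membered aromatic ring of carbon only that is part of a fused or bridged system of two rings, accepts a group of 4 heavy atoms with 1 hydrogen-bond donor and 1 hydrogen-bond acceptor in place of a single fluorine, and that the half-life moves up rather than down with this exchange. Nothing at hand gives a measured reason for this rise.

The compounds shown leave open whether the rise belongs to the arrival of methylcarbamoyl or to the departure of fluoro, a question that a plain hydrogen, a primary carboxamide or a carboxylic acid at the same place could help to settle. They also leave open whether the same exchange would carry over to the cores of compound 1 and compound 3.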